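The source may report more compounds than this note shows. Statements on the series, on what has been measured and on what is new or still open speak of the compounds shown alone.

In a functional assay on K562 cells (Homo sapiens) for antiproliferative activity, with a stated time of 72 h (on this read-out higher numbers stand for weaker inhibition and lower numbers for stronger inhibition), compound 1 `OC[C@H]1O[C@@H](n2cnc3c(NCc4cccc(Br)c4)ncnc32)[C@H](O)[C@@H]1O` gives 19700 nM. Compound 2 `Cc1ccc(CNc2ncnc3c2ncn3[C@@H]2O[C@H](CO)[C@@H](O)[C@H]2O)cc1` is reported only as a limit, > 166000 nM. Compound 3 `OC[C@H]1O[C@@H](n2cnc3c(NCc4c(F)ccc(F)c4F)ncnc32)[C@H](O)[C@@H]1O` is also reported only as a limit, > 166000 nM, and so stands at the limit of > 166000 nM in this assay, at which 2 of the 3 values shown sit. Compound 4 `OC[C@H]1O[C@@H](n2cnc3c(NCc4ccccc4OC(F)F)ncnc32)[C@H](O)[C@@H]1O` differs from it by 2-(difluoromethoxy)phenyl in place of 2,3,6-trifluorophenyl on a saturated chain carbon bound to a nitrogen on an aromatic ring. Within the data shown here, the steps that bear on this change are an at least 8.4-fold higher number from compound 1 to compound 2 (0.92 log units; beyond the scatter) and an at least 8.4-fold higher number from compound 1 to compound 3 (0.92 log units; beyond the scatter), while a step that the two limits leave unreadable from compound 2 to compound 3 gives no size. Of these compounds, only compound 1 gives an exact number, 19700 nM, so a move down is possible but remains uncertain. The expected change is an at least 2.3-fold lower number from compound 3 to compound 4 (0.37 log units; beyond the scatter), towards a lower number, though another limit is about as likely. Compound 4 is estimated at 70000 nM, within an expected range of 18000 nM to 166000 nM.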

Compound 4, half-maximal inhibitory concentration: > 166000 nM
Compound 4: no number, only a limit (the forecaster's own chance of this, stated with the estimate: 50%); middle value at least 2.3-fold (0.37 log units) away from the limit.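

In this assay compound 4 is also reported only as a limit, so 2-(difluoromethoxy)phenyl, with its oxygen, joins 4-methylphenyl and 2,3,6-trifluorophenyl without a number, and the steps among these three cannot be read. Among these compounds, the one readable step is an at least 8.4-fold higher number from compound 1 to compound 4 (0.92 log units; beyond the scatter), which leaves 3-bromophenyl as the only group here with an exact value. The position now looks more sharply limited: the limit of > 166000 nM in this assay, at which 3 of the 4 values shown sit.

Going by these compounds, whether the three groups at the limit differ among themselves remains open. So does whether compound 1 owes its number to the bromine, a question that 3-chlorophenyl or 3-methylphenyl would address.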